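Methyl in place of fluoro: compound 3 to compound 4

This account rests on a few compounds, and the source may have more. Where it says the series, first, only, none or still open, it means among the compounds named here.

Three compounds of the series have been run in a functional assay on the whole organism with Rattus norvegicus as the target; on this read-out higher numbers stand for an effect only at larger amounts of compound and lower numbers for an effect already at smaller amounts. Compound 1 `C[C@@H]1CC/C(=N\Nc2ccccc2)c2ncc(C(=O)O)c(=O)n21` gives 54.8 umol/kg. Compound 2 `CC1CCN2C(=O)C(C(=O)O)=CNC2=C1/C=N/c1ccccc1C(=O)O` gives 100 umol/kg. Compound 3 `CC1CCC(/C=N/c2ccc(F)cc2)=C2NC=C(C(=O)O)C(=O)N21` gives 10.6 umol/kg, the lowest of the three numbers; its gaps to compound 1 and to compound 2 both lie beyond the scatter of repeated measurements, so compound 3 is the most potent of the measured set. Among the compounds with values here, no two of the measured compounds differ in a single place, so no measured step is available to calibrate the change considered here.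

Compound 4 `Cc1ccc(/N=C/C2=C3NC=C(C(=O)O)C(=O)N3C(C)CC2)cc1` differs from compound 3 in one place: methyl in place of fluoro on an aromatic carbon. Within the data shown here, nothing among the measured compounds shows the effect of this exchange, and no direction can be read from them. The expected step is small, plausibly within the scatter, with no preferred direction. Compound 4 is expected to give 12 umol/kg in this assay, within 5 umol/kg to 30 umol/kg. The estimated step of a 1.1-fold higher number from compound 3 to compound 4 (0.05 log units; within the scatter) is accordingly close to flat.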

Compound 4, dose for 50% inhibition: 3.6 umol/kg
The estimate for compound 4 lay 3.3-fold (0.52 log units) above the measured number; measured number below the stated range.
By their numbers in this assay, from the lowest: compound 4; then compound 3; then compounds 1 and 2 (each within the scatter of the next).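

In this assay, within the data shown here, methyl in place of fluoro on an aromatic carbon, para to a large group, gives a 2.9-fold lower number from compound 3 to compound 4 (0.47 log units; beyond the scatter) and this is the first step that differs in one place. The position is therefore not indifferent to this exchange: going from 4-fluorophenyl to 4-methylphenyl lowers the number beyond the scatter, although one heavy atom replaces one heavy atom and the counts of hydrogen-bond donors, acceptors and net charge stay the same. Nothing available here accounts for the size or direction of this step.

One exchange at one position cannot show whether the gain comes from having methyl or from losing fluoro. Open too, from the compounds shown here alone, is how a longer chain such as ethyl, or a methoxy group or an amine, would read at this position.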